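Bromo to hydrogen on the core: outlook for compound 4

This account rests on a few compounds, and the source may have more. Where it says the series, first, only, none or still open, it means among the compounds named here.

Working notes on a small set of acylhydrazones assessed in a functional assay on DU-145 cells (Homo sapiens) for cytotoxicity; on this read-out lower numbers stand for stronger inhibition and higher numbers for weaker inhibition. Compound 1 `COc1ccc2c(c1)c(/C=N\NC(=O)c1c[nH]c3ccc(Br)cc13)cn2Cc1ccc(Cl)cc1` gives 57000 nM in this assay. Compound 2 `COc1ccc2c(c1)c(/C=N\NC(=O)c1c[nH]c3ccccc13)cn2Cc1ccc(Cl)cc1` is related to compound 1 by hydrogen in place of bromo on an aromatic carbon; in this assay compound 2 gives 50000 nM, and the step is a 1.1-fold lower number from compound 1 to compound 2 (0.06 log units; within the scatter). Compound 3 `COc1ccc(Cn2cc(/C=N\NC(=O)c3c[nH]c4ccc(Br)cc34)c3ccc(F)cc32)cc1` gives 67500 nM in this assay. The difference between the core of compound 3 and the core of compound 1 is not broken down here; the values of compound 3 and compound 1 lie within the scatter of each other, as do those of compound 3 and compound 2, so no order can be read among these three.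

Compound 4 `COc1ccc(Cn2cc(/C=N\NC(=O)c3c[nH]c4ccccc34)c3ccc(F)cc32)cc1` has not yet been measured in this assay. It is related to compound 3 by hydrogen in place of bromo on an aromatic carbon. The place is described in the same words as for the pair of compound 1 and compound 2, so this is the same change, and it is the only other occurrence of that change among the compounds shown.

Because the earlier step of a 1.1-fold lower number from compound 1 to compound 2 (0.06 log units; within the scatter) stayed within the scatter, compound 4 is expected to sit close to compound 3. The expected step is a 1.1-fold lower number from compound 3 to compound 4 (0.04 log units; within the scatter), taken as the same small movement seen before. Compound 4 is estimated at 61000 nM in this assay, with a likely range from 35000 nM to 110000 nM; a single precedent within the scatter gives only a rough anchor, and the series as a whole shows weak inhibition, so a reported limit rather than a number cannot be ruled out.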

Compound 4, half-maximal inhibitory concentration: 16200 nM
The estimate for compound 4 lay 3.8-fold (0.58 log units) above the measured number; the whole stated range lies above it.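

In this assay the change from 5-bromo-1H-indol-3-yl to 1H-indol-3-yl now gives a 4.2-fold lower number from compound 3 to compound 4 (0.62 log units; beyond the scatter), a modest step and the only one in this set that stands clear of the scatter. Hydrogen in place of bromo on an aromatic carbon therefore does not carry a fixed size from one core to the other, and the small step seen earlier is a poor guide to the step on the second core: the same change on two cores in this assay, a 1.1-fold lower number (0.06 log units; within the scatter) from compound 1 to compound 2 and a 4.2-fold lower number (0.62 log units; beyond the scatter) from compound 3 to compound 4, 3.7-fold (0.56 log units) apart, beyond the scatter of two such steps

Two pairs show that the core can matter for this change, but they do not show which of the differences between the core of compound 1 and the core of compound 3 is responsible, nor which of the two steps would be the more typical on a third core.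

On these data alone, it remains open whether the lower number of compound 4 is specific to losing the bromo group, or whether other replacements at the same aromatic carbon, such as a nitrile, an amine or a carboxylic acid, would move the value on this core as well. Also open, as far as these compounds go, is how the change behaves on a core that carries only one of the features separating the two cores, which would begin to show where the difference between the steps arises.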